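The source may hold more compounds than are shown below. What is called first, only, known or untested is meant among the compounds shown, and "the series" means these compounds.

In a functional assay on CCRF-CEM cells (Homo sapiens) for antiproliferative activity, read by MTT assay, with a stated time of 72 h (on this read-out lower numbers stand for stronger inhibition and higher numbers for weaker inhibition), compound 1 (`C=C(Br)C(=O)Nc1ccc2c(c1)/C(=C/c1ccc[nH]1)C(=O)N2`) gives 3 nM and stands lowest of the two numbers measured, while compound 2 (`C#CC(=O)Nc1ccc2c(c1)/C(=C/c1ccc[nH]1)C(=O)N2`) gives 50 nM as the higher one. For the measured compounds named here, the one measured step (a 17-fold higher number from compound 1 to compound 2 (1.22 log units; beyond the scatter)) is large and puts ethynyl in place of 1-bromoethenyl on a carbonyl carbon. Compound 3 (`C=C(Br)C(=O)Nc1ccc2c(c1)/C(=C/c1sccc1C)C(=O)N2`) keeps the 1-bromoethenyl of compound 1 and differs elsewhere (3-methylthiophen-2-yl in place of 1H-pyrrol-2-yl on a double-bonded chain carbon bound to a double-bonded ring carbon), with 3-methylthiophen-2-yl in place of 1H-pyrrol-2-yl. Going by the values given here, no measured step touches that place, so the large step bears on it only indirectly and gives no direction. Since compound 1 sits at 3 nM as the lowest number, a moderate rise in this assay is expected, smaller than the measured step. The expected step is moderate (a 4.0-fold higher number from compound 1 to compound 3 (0.60 log units; beyond the scatter)) in size. Compound 3 is estimated at 12 nM and expected to fall between 2 nM and 60 nM on measurement.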

Compound 3, half-maximal inhibitory concentration: 0.5 nM
Compound 3: middle estimate off by 24-fold (1.38 log units), on the high side; the measured number lies below the stated range.
By their numbers in this assay, from the lowest: compound 3; then compound 1; then compound 2.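

In this assay the place on a double-bonded chain carbon bound to a double-bonded ring carbon proves open to change: with the 1-bromoethenyl kept, 3-methylthiophen-2-yl in place of 1H-pyrrol-2-yl gives a 6.0-fold lower number from compound 1 to compound 3 (0.78 log units; beyond the scatter) and so moves the number down, not up. The entering group has no hydrogen-bond donor, so the donor of 1H-pyrrol-2-yl is not needed for a low number in this assay. No measurement given here accounts for the drop.

On these data alone, what a thiophen-2-yl without the methyl or a 3-methyl-1H-pyrrol-2-yl would give at this place stays open, so the shares of the sulfur and the methyl cannot be separated. Also open, as far as these compounds go, is whether 3-methylthiophen-2-yl would lower the number in the same way with the ethynyl of compound 2 on the carbonyl carbon.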